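The source may report more compounds than this note shows. Statements on the series, on what has been measured and on what is new or still open speak of the compounds shown alone.

Going by the values given here, the two compounds measured so far share one core and differ only in the chain on a saturated ring carbon. Compound 1 `CCOCC1CN(c2ccccc2)NC1=O` carries an ethoxymethyl chain, and in an assay on isolated protein for inhibition of Polyunsaturated fatty acid 5-lipoxygenase (Rattus norvegicus) (on this read-out higher numbers stand for weaker inhibition and lower numbers for stronger inhibition), compound 1 gives 280 nM. Compound 2 `CCOCCC1CN(c2ccccc2)NC1=O` carries a 2-ethoxyethyl chain, and in this assay compound 2 gives 150 nM. Among the compounds with values here, the step of a 1.9-fold lower number from compound 1 to compound 2 (0.27 log units; within the scatter) is the only one measured, and it lies within the scatter; compound 2 therefore stands at one end of two numbers that cannot be told apart, with compound 1 as its sole neighbour.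

Compound 3 `CN(C)CCC1CN(c2ccccc2)NC1=O` is not yet measured. It differs from compound 2 by dimethylamino in place of ethoxy on a saturated chain carbon, two bonds along the chain from a saturated ring carbon. Within the data shown here, no measured step exchanges an ethoxy for a dimethylamino; the only step available, from compound 1 to compound 2, lengthened the chain and stayed within the scatter, so it bears on the new change only in showing that this chain has tolerated one alteration without a step beyond the scatter. On that basis the step from compound 2 to compound 3 in this assay is expected to be a 1.3-fold higher number from compound 2 to compound 3 (0.12 log units; within the scatter), with no direction favoured. Compound 3 is accordingly estimated at 200 nM, with a range from 60 nM to 700 nM to allow for the untested exchange.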

Compound 3, half-maximal inhibitory concentration: > 1000 nM
Compound 3 ended at the assay's limit; the forecaster's own chance of this, stated with the estimate: 5%; middle value at least 5.0-fold (0.69 log units) from the limit.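

For compound 3 the read-out in this assay is a limit of the assay and not a number: the limit of > 1000 nM in this assay, at which 1 of the 3 values shown sits.

Even as a limit it shows something the earlier compounds could not. Going by these compounds alone, exchanging ethoxy for dimethylamino leaves the counts of heavy atoms and hydrogen-bond acceptors unchanged, yet it gives an at least 6.6-fold higher number from compound 2 to compound 3 (0.82 log units; beyond the scatter) on this read-out, so the chain at this position does not accept every change as it accepted the one step within the scatter. Measured against the ethoxymethyl chain, the result points the same way, with an at least 3.5-fold higher number from compound 1 to compound 3 (0.55 log units; beyond the scatter) for the change to the 2-(dimethylamino)ethyl chain, so the weaker inhibition holds against both ether chains shown.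

The true size of both steps stays open, since the compounds shown fix only their lower bounds. They also do not tell whether a primary amine, a morpholine ring, a methoxy group or a longer ether chain at this place would behave like ethoxy or like dimethylamino, and so they do not separate the effect of the nitrogen from that of the rest of the group.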